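Swapping the carbamate end for an aminobenzamide

The compounds below may be only part of what the source reports. "The series", "measured", "known", "first", "only" and "open" are said of these compounds alone.

Compound 2 `CCOC(=O)Nc1ccc(S(=O)(=O)N2C[C@H](c3ccccc3)NC2=O)cc1CC` sits second highest of the three numbers in a functional assay on NCI-H460 cells (Homo sapiens) for cytotoxicity, read by MTT assay (a higher number here means a weaker inhibitor, a lower number a stronger inhibitor), where compound 2 gives 70 nM. Compound 1 `CCCCOC(=O)Nc1ccc(S(=O)(=O)N2C[C@H](c3ccccc3)NC2=O)cc1CC` gives 200 nM, and compound 3 `CCOC(=O)Nc1ccc(S(=O)(=O)N2C[C@H](c3ccccc3)NC2=O)cc1Cl` gives 20 nM. Compound 4 `CCc1cc(S(=O)(=O)N2C[C@H](c3ccccc3)NC2=O)ccc1NC(=O)c1ccc(N)cc1` is not yet measured. It differs from compound 2 by 4-aminophenyl in place of ethoxy on a carbonyl carbon.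

Two measured steps surround compound 2. Shortening the chain on the carbamate end, a 2.9-fold lower number from compound 1 to compound 2 (0.46 log units; beyond the scatter), shows that this end of the molecule moves the number. Trading the ring substituent, a 3.5-fold lower number from compound 2 to compound 3 (0.54 log units; beyond the scatter), touches a different place and does not bear on the present change. Neither step replaces an alkoxy group with an aromatic ring on the carbonyl carbon, so the direction of the new step is open; the carbamate end is sensitive, so a change beyond the scatter in either direction is possible. Compound 4 is expected to give about 100 nM, within 25 nM to 400 nM, which means an expected step of a 1.4-fold higher number from compound 2 to compound 4 (0.15 log units; within the scatter).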

Compound 4, half-maximal inhibitory concentration: 670 nM
Beside the measured number, compound 4's estimate is 6.7-fold (0.83 log units) below it; measured number outside the range, above it.
By their numbers in this assay, from the lowest: compound 3; then compound 2; then compound 1; then compound 4.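

In this assay, the carbonyl carbon on the amide-type nitrogen proves far less forgiving of 4-aminophenyl than of a simple alkoxy chain, with a 9.6-fold higher number from compound 2 to compound 4 (0.98 log units; beyond the scatter) as the largest step among these compounds. The earlier compounds shown here showed only that this end of the molecule responds to a change of chain length, whereas the ring now pushes the number past even the butoxy compound, with a 3.4-fold higher number from compound 1 to compound 4 (0.53 log units; beyond the scatter) as the step. No measurement given here explains this rise.

From the compounds shown here alone, the change swaps the ethoxy for a ring and adds an amino group in one move, so the share of each remains unknown. Going by these compounds, a plain phenyl group would separate those two parts, and whether the same swap behaves alike with chloro in place of the ring's ethyl also remains open.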